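This account rests on a few compounds, and the source may have more. Where it says the series, first, only, none or still open, it means among the compounds named here.

Compound 1 `CC1(C)[C@@H]2CC[C@@]1(CS(=O)(=O)N1CCN(c3ncccc3C(F)(F)F)CC1)C(=O)C2`: > 31600 nM
Compound 2 `CC1CN(c2ccc(C(F)(F)F)cn2)CCN1S(=O)(=O)C[C@]12CC[C@H](CC1=O)C2(C)C`: 631 nM
Compound 3 `C[C@@H]1CN(c2ccc(C(F)(F)F)cn2)[C@@H](C)CN1S(=O)(=O)C[C@]12CC[C@H](CC1=O)C2(C)C`: 6310 nM

Three compounds share a bicyclic ketone core joined through a sulfonylmethyl link to a six-membered ring with two nitrogens that carries a pyridyl group. In a functional assay on CHO-K1 cells for antagonist activity at C-X-C chemokine receptor type 3 (Homo sapiens), read by FLIPR and calcium flux (on this read-out higher numbers stand for weaker inhibition and lower numbers for stronger inhibition), compound 1 gives > 31600 nM, which is a limit of the assay and not a number. Compound 1 therefore stands at the weak end of what has been measured, a point marked by the limit of > 31600 nM in this assay, at which 1 of the 3 values shown sits. Compound 2 gives 631 nM in this assay and compound 3 gives 6310 nM; both differ from compound 1 in more than one place, so their values are given here only as they stand.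

Compound 4 `CC1(C)[C@@H]2CC[C@@]1(CS(=O)(=O)N1CCN(c3ccc(Br)cn3)CC1)C(=O)C2` has not yet been measured. The change from compound 1 is 5-bromopyridin-2-yl in place of 3-(trifluoromethyl)pyridin-2-yl on an amine nitrogen in a ring. Among the compounds with values here, since compound 1 offers only a limit, no measured step defines what this exchange does. Compound 4 is expected to move toward the values of compounds 2 and 3, with the step of an at least 21-fold lower number from compound 1 to compound 4 (1.32 log units; beyond the scatter) estimated as a clear gain. The estimated value of compound 4 in this assay is 1500 nM, within 250 nM to 12000 nM.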

Compound 4, half-maximal inhibitory concentration: 1580 nM
Beside the measured number, compound 4's estimate is 1.1-fold (0.02 log units) below it, and the stated range covers the measured number.
By their numbers in this assay, from the lowest: compound 2; then compound 4; then compound 3. At a limit, above all of these: compound 1.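

In this assay, exchanging 3-(trifluoromethyl)pyridin-2-yl for 5-bromopyridin-2-yl on an amine nitrogen in a ring gives an at least 20-fold lower number from compound 1 to compound 4 (1.30 log units; beyond the scatter), the first step measured in this series, and it shows that the group at this place can decide whether a readable value appears on the shared core. The size of this step is open-ended, since compound 1 remains a limit of the assay and not a number: the limit of > 31600 nM in this assay, at which 1 of the 4 values shown sits. Within the data shown here, the exchange replaces the substituent and also moves it on the pyridine, so the single step does not separate these two changes.

Going by these compounds, what a 3-bromopyridin-2-yl group would give at this place remains open, and this group would keep the substituent's location from compound 1 while carrying the bromine of compound 4. Also open, on these data alone, is how far a 5-chloropyridin-2-yl group or a plain phenyl ring would hold the value of compound 4.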